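This account rests on a few compounds, and the source may have more. Where it says the series, first, only, none or still open, it means among the compounds named here.

Compounds measured so far:
- compound 1, `O=C(Nc1ccccc1F)C(Cl)Cl`: 87500 nM
- compound 2, `O=C(Nc1ccccc1Cl)C(Cl)Cl`: 50200 nM
- compound 3, `O=C(Nc1cccc(Cl)c1)C(Cl)Cl`: 14800 nM

In a functional assay on A549 cells (Homo sapiens) for antiproliferative activity, read by MTT assay, with a stated time of 72 h (a higher number here means a weaker inhibitor, a lower number a stronger inhibitor), compound 3 gives the lowest of the three numbers: compound 2 sits a 1.7-fold lower number from compound 1 to compound 2 (0.24 log units; within the scatter) away from compound 1, a gap inside the scatter, whereas the values of compound 2 and compound 3 lie apart by more than the scatter, with compound 3 the lower.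

Compound 4, `O=C(Nc1cccc(SC(F)(F)F)c1)C(Cl)Cl`, differs from compound 3 in one place: (trifluoromethyl)sulfanyl in place of chloro on an aromatic carbon. Among the measured compounds shown here, none of the measured steps covers this exchange. For the measured compounds named here, the only measured step, a 1.7-fold lower number from compound 1 to compound 2 (0.24 log units; within the scatter), swaps one halogen for another on an aromatic carbon and stays within the scatter; a (trifluoromethyl)sulfanyl group entering for chloro is a larger change and no measured pair informs it. The expectation for compound 4 in this assay is therefore a step of modest size, most likely toward a lower number but not securely beyond the scatter, giving an estimated 1.9-fold lower number from compound 3 to compound 4 (0.27 log units; within the scatter). Compound 4 is expected at about 8000 nM, between 2500 nM and 30000 nM.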

Compound 4, half-maximal inhibitory concentration: 14100 nM
For compound 4 the middle estimate is 1.8-fold (0.25 log units) below the measured one, and the stated range covers the measured number.
By their numbers in this assay, from the lowest: compounds 4 and 3 (each within the scatter of the next); then compounds 2 and 1 (each within the scatter of the next).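

In this assay, replacing chloro with (trifluoromethyl)sulfanyl on the aromatic carbon meta to a group of 6 heavy atoms gives a 1.0-fold lower number from compound 3 to compound 4 (0.02 log units; within the scatter) and leaves the read-out where it was. Until now the only listed exchange was one halogen for another, whereas here 5 heavy atoms, including a sulfur, enter where 1 chlorine leaves. This place on the ring therefore accepts a much larger group without any change beyond the scatter, so the read-out here does not follow the size of the group across this pair.

As far as these compounds go, whether an amine, a carboxylic acid or a longer alkyl chain at this place would also read like chloro remains open, as does the effect of the same exchange elsewhere on the ring. Nothing shown here bears on why chloro and (trifluoromethyl)sulfanyl read alike.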